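The source may hold more compounds than are shown below. What is called first, only, known or untested is meant among the compounds shown, and "the series" means these compounds.

Measured so far in an ADME assay on CCRF-CEM cells (Homo sapiens) for antiproliferative activity, with a stated time of 48 h; on this read-out lower numbers stand for stronger inhibition and higher numbers for weaker inhibition:
compound 1 `C=C(Br)C(=O)Nc1ccc(/C=C/C(=O)c2ccccc2)cc1` gives 4000 nM
compound 2 `C=C(Br)C(=O)Nc1ccc(/C=C/C(=O)c2cc(OC)c(OC)c(OC)c2)cc1` gives 1100 nM
compound 3 `Nc1ccc(/C=C/C(=O)c2ccccc2)cc1` gives 34000 nM

Compound 1 and compound 3 share a core and differ in one place: hydrogen in place of (1-bromoethenyl)carbonyl on a nitrogen on an aromatic ring. That change brought an 8.5-fold higher number from compound 1 to compound 3 (0.93 log units; beyond the scatter), so removing the (1-bromoethenyl)carbonyl weakened the compound. Compound 2 carries the same (1-bromoethenyl)carbonyl on a different core; how the two cores differ is not broken down here. Compound 2 stands lowest of the three numbers, a step beyond the scatter from compound 1 and a far larger one from compound 3.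

Compound 4 `COc1cc(C(=O)/C=C/c2ccc(N)cc2)cc(OC)c1OC` is not yet measured. It relates to compound 2 as compound 3 relates to compound 1: hydrogen in place of (1-bromoethenyl)carbonyl on a nitrogen on an aromatic ring. The place is the same in both pairs, so this is the same change made on a second core. If the change behaves as it did before, compound 4 is expected to sit at an 8.2-fold higher number from compound 2 to compound 4 (0.91 log units; beyond the scatter) in this assay, a step resting on an 8.5-fold higher number from compound 1 to compound 3 (0.93 log units; beyond the scatter) and on compound 2 at 1100 nM. The expected value for compound 4 is therefore 9000 nM, estimated to fall between 3000 nM and 30000 nM.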

Compound 4, half-maximal inhibitory concentration: 2500 nM
The estimate for compound 4 lay 3.6-fold (0.56 log units) above the measured number; the whole stated range lies above it.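

Taking the (1-bromoethenyl)carbonyl off the nitrogen on the second core weakened the compound again in this assay, giving a 2.3-fold higher number from compound 2 to compound 4 (0.36 log units; beyond the scatter). The direction of the change therefore carried over from one core to the other, but its size did not: the same change on two cores in this assay, an 8.5-fold higher number (0.93 log units; beyond the scatter) from compound 1 to compound 3 and a 2.3-fold higher number (0.36 log units; beyond the scatter) from compound 2 to compound 4, 3.7-fold (0.57 log units) apart, beyond the scatter of two such steps

A newcomer can take from this that a step measured on one core gave the right sign on the other but was not a reliable guide to its size; these two pairs do not show why the size depends on the core, and they make no rule for other cores.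

From the compounds shown here alone, it stays open how an acetyl group, or an acryloyl group without the bromine, would compare on a nitrogen on an aromatic ring, so the part of the (1-bromoethenyl)carbonyl that matters cannot be told from these compounds. Going by these compounds, whether the step would keep its direction on a third core also stays open.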